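Swapping chloro for methoxy on the styryl ring

The source may hold more compounds than are shown below. What is called first, only, known or untested is meant among the compounds shown, and "the series" means these compounds.

Measured compounds:
Compound 1, `CO/C(=C\c1ccc(F)cc1)C(=O)Nc1ccc(OC)cc1`: 13500 nM
Compound 2, `CO/C(=C\c1ccc(Cl)cc1)C(=O)Nc1ccc(F)cc1`: 14000 nM
Compound 3, `CO/C(=C\c1ccc(Cl)cc1)C(=O)Nc1ccc(C)cc1`: 12700 nM

In a functional assay on cells (Splenocyte, Mus musculus, strain BALB/c) for inhibition, read by MTT assay, with a stated time of 48 h (on this read-out lower numbers stand for stronger inhibition and higher numbers for weaker inhibition), compound 3 gives the lowest of the three numbers, yet the gaps to compound 1 and to compound 2 both lie within the usual scatter, so the three compounds cannot be told apart on these data. Compound 4, `CO/C(=C\c1ccc(OC)cc1)C(=O)Nc1ccc(C)cc1`, differs from compound 3 in one place: methoxy in place of chloro on an aromatic carbon.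

Among the compounds with values here, only one measured step of a single change exists, a 1.1-fold lower number from compound 2 to compound 3 (0.04 log units; within the scatter), and it concerns a different group on the other ring. Compound 1 and compound 2 differ in two places at once, so their values show only that both sit close to compound 3. Within the data shown here, no measured pair shows what methoxy in place of chloro on an aromatic carbon does in this assay. Given that every change seen so far left the number within the scatter, the expectation for compound 4 is a step of about a 1.0-fold higher number from compound 3 to compound 4 (0.01 log units; within the scatter), that is, none beyond the scatter. Compound 4 is therefore estimated at 13000 nM, with a range from 6000 nM to 28000 nM.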

Compound 4, half-maximal inhibitory concentration: 940 nM
Compound 4: the middle estimate sits 14-fold (1.14 log units) above what was measured; the whole stated range lies above it.
By their numbers in this assay, from the lowest: compound 4; then compounds 3, 1 and 2 (each within the scatter of the next).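

In this assay, methoxy in place of chloro on an aromatic carbon, para to a large group, gives a 14-fold lower number from compound 3 to compound 4 (1.13 log units; beyond the scatter) and so separates compound 4 from the other compounds shown. Within the data shown here, the only earlier single change, a 1.1-fold lower number from compound 2 to compound 3 (0.04 log units; within the scatter), was made on the other ring and stayed within the scatter, so this is the first sign that the number responds strongly to a change in the shared core and that the group at this position matters. Leaving chloro and entering methoxy adds one heavy atom and one hydrogen-bond acceptor, but nothing measured here shows why the number falls so sharply.

The compounds shown leave open whether the drop belongs to methoxy in particular, or whether a hydroxyl, an ethoxy group or an amine at the same position would give a similar number. They also leave open whether the step holds when the methyl on the other ring is replaced by another group, such as fluoro, since it has been read against only one partner.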